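Trading trifluoromethyl for fluoro on a stable compound

The compounds below may be only part of what the source reports. "The series", "measured", "known", "first", "only" and "open" are said of these compounds alone.

In an ADME assay on microsomes from liver (Homo sapiens) for metabolic stability, with a stated time of 10 min, tested at 0.5 uM (on this read-out lower numbers stand for a less stable compound and higher numbers for a more stable compound), compound 1 `CCC(c1nc2ncc(Cl)cc2[nH]1)[C@H]1CC[C@@H](c2ccnc3ccc(C(F)(F)F)cc32)CC1` gives 81%, within the scatter of compound 3 `CCC(Nc1nnc(-c2ccc(OC)cc2)o1)[C@H]1CC[C@H](Oc2ccnc3ccccc23)CC1` at 83%. Compound 2 `COc1ccc(Nc2nnc([C@H](C)[C@H]3CC[C@@H](c4ccnc5ccc(F)cc54)CC3)o2)cc1` gives 18%, far lower than both and beyond the scatter. Compound 4 `CCC(c1nc2ncc(Cl)cc2[nH]1)[C@H]1CC[C@@H](c2ccnc3ccc(F)cc32)CC1` differs from compound 1 in one place: fluoro in place of trifluoromethyl on an aromatic carbon. Among the compounds with values here, no measured pair isolates this change. Compound 2 also carries fluoro on an aromatic carbon and gives 18%, but it differs from compound 1 elsewhere too, so only a moderate loss in this assay is expected, probably beyond the scatter. The expected step is a number 19 percentage points lower from compound 1 to compound 4 (beyond the scatter). For compound 4 the estimate is 62%, with an expected range from 35% to 82%.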

Compound 4, percent of the compound remaining: 78%
Estimate against measurement, compound 4: 16 percentage points below; the measured number falls inside the stated range.
By their numbers in this assay, from the lowest: compound 2; then compounds 4, 1 and 3 (each within the scatter of the next).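

Fluoro in place of trifluoromethyl on this aromatic carbon now has a direct reading in this assay: a number 3 percentage points lower from compound 1 to compound 4 (within the scatter). At this position, with the rest of the core of compound 1 unchanged, the smaller group gives a number indistinguishable from that of trifluoromethyl, so trifluoromethyl is not required here for stability in this read-out. Nothing measured bears on why the two groups read alike.

Open, on these data alone, is whether a nitrile or an amine on this carbon would read the same. Also open, as far as these compounds go, is whether the same exchange holds on a different core.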